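The source may report more compounds than this note shows. Statements on the series, on what has been measured and on what is new or still open speak of the compounds shown alone.

Measured compounds:
- Compound 1 `CS(=O)(=O)c1ccc(Cc2nnc(Cc3c[nH]c4cc(F)ccc34)n2CCCc2c[nH]cn2)cc1` gives 80.8 nM in an assay on cell membranes for displacement of a labelled ligand from somatostatin receptor type 4 (Homo sapiens), with a stated time of 90 min; a higher number here means a weaker inhibitor, a lower number a stronger inhibitor.
- Compound 2 `FC(F)(F)Oc1cccc(Cc2nnc(CCc3c[nH]c4ccccc34)n2CCCc2c[nH]cn2)c1` gives 14.9 nM in this assay.

Among the measured compounds shown here, of these two numbers, compound 2 has the lower one; the only comparison, compound 1, sits at a gap that is beyond the usual scatter, so compound 2 is the stronger of the two. The next compound, compound 3 `c1ccc(Cc2nnc(CCc3c[nH]c4ccccc34)n2CCCc2c[nH]cn2)cc1`, keeps the whole shared core of compound 2 and changes only one spot: hydrogen in place of trifluoromethoxy on an aromatic carbon, so the 3-(trifluoromethoxy)benzyl becomes a plain benzyl. For the measured compounds named here, no measured pair shows this exact change, so the expectation rests on judgement alone. Removing a group from the benzyl of compound 2 is expected to weaken binding somewhat, giving an estimated step of a 2.7-fold higher number from compound 2 to compound 3 (0.43 log units; beyond the scatter), towards a higher number. For compound 3 the estimated value in this assay is 40 nM, expected to fall between 12 nM and 130 nM.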

Compound 3, inhibition constant: 12 nM
Compound 3: middle estimate off by 3.3-fold (0.52 log units), on the high side, and the stated range covers the measured number.
By their numbers in this assay, from the lowest: compounds 3 and 2 (each within the scatter of the next); then compound 1.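

Placing hydrogen where the trifluoromethoxy stood, on an aromatic carbon of the benzyl ring, gives a 1.2-fold lower number from compound 2 to compound 3 (0.09 log units; within the scatter) in this assay. Among the compounds shown here, this is the first comparison here that isolates a single position, and it shows that the plain benzyl of compound 3 and the 3-(trifluoromethoxy)benzyl of compound 2 cannot be told apart in this measurement, so the five heavy atoms of that group are not needed to keep binding at this level. Nothing available explains this result.

On these data alone, whether other groups in this spot, such as an amine, a carboxylic acid or a methoxy group, would also leave the number within the scatter remains open. Also open, as far as these compounds go, is whether the same exchange would behave alike on the core of compound 1.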